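Swapping an ethyl for two chlorines on the anilino ring

A few compounds are considered here, and "the series" means these few. Any claim that something is new, unique, unknown or untested is made for them only; others in the source may bear on it.

Compound 3 `C=CC(=O)Nc1cccc(NC(=O)CSc2nc(Nc3ccc(CC)cc3)c3ccccc3n2)c1` gives 14400 nM in a functional assay on MDA-MB-231 cells (Homo sapiens) for inhibition, read by MTT assay, with a stated time of 72 h; on this read-out lower numbers stand for stronger inhibition and higher numbers for weaker inhibition. Compound 2 `C=CC(=O)Nc1cccc(NC(=O)CSc2nc(Nc3cccc(C)c3)c3ccccc3n2)c1` gives 16800 nM in this assay, and a 1.2-fold lower number from compound 2 to compound 3 (0.07 log units; within the scatter) lies within the scatter, so the two numbers are not told apart. Compound 1 `C=CC(=O)Nc1cccc(NC(=O)CSc2nc(Nc3cccc([N+](=O)[O-])c3)c3ccccc3n2)c1` reaches only a limit of this assay, > 50000 nM, as recorded in the limit of > 50000 nM in this assay, at which 1 of the 3 values shown sits. From there the alkyl analogues improve: an at least 2.9-fold lower number from compound 1 to compound 2 (0.47 log units; beyond the scatter) and an at least 3.4-fold lower number from compound 1 to compound 3 (0.54 log units; beyond the scatter).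

Compound 4 `C=CC(=O)Nc1cccc(NC(=O)CSc2nc(Nc3ccc(Cl)c(Cl)c3)c3ccccc3n2)c1` carries 3,4-dichlorophenyl in place of 4-ethylphenyl on a nitrogen on an aromatic ring. Among the compounds with values here, the only measured aryl-to-aryl swap, from compound 2 to compound 3, stayed within the scatter, while a nitro group pushed the number past the limit; a dichloro pattern has no precedent here. Compound 4 is therefore expected near 13000 nM, between 4000 nM and 45000 nM, a step of a 1.1-fold lower number from compound 3 to compound 4 (0.04 log units; within the scatter) that is expected to remain within the scatter.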

Compound 4, half-maximal inhibitory concentration: 17700 nM
Compound 4: middle estimate off by 1.4-fold (0.13 log units), on the low side, and the stated range covers the measured number.
By their numbers in this assay, from the lowest: compounds 3, 2 and 4 (each within the scatter of the next). At a limit, above all of these: compound 1.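

In this assay the 3,4-dichlorophenyl group on this nitrogen cannot be told apart from the alkyl-bearing rings, with a 1.2-fold higher number from compound 3 to compound 4 (0.09 log units; within the scatter) and with a 1.1-fold higher number from compound 2 to compound 4 (0.02 log units; within the scatter). Two chlorine atoms in place of the ethyl therefore bring no readable change, and the one ring that stands apart remains the 3-nitrophenyl, with an at least 2.8-fold lower number from compound 1 to compound 4 (0.45 log units; beyond the scatter). Compound 1 itself sits at a limit, not at a number: the limit of > 50000 nM in this assay, at which 1 of the 4 values shown sits. The compounds shown leave open whether an amine or a carboxylic acid on this ring would lower the number.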